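The compounds below may be only part of what the source reports. "The series", "measured", "known", "first", "only" and "open" are said of these compounds alone.

Compound 2 `CCOc1ccc2nc(C(=O)Nc3c(F)cc(-c4cccc(F)c4)cc3F)c(C)c(O)c2c1` is the lower of the two compounds measured in a functional assay on Hep 3B2 cells (Homo sapiens) for antiproliferative activity, read by MTT assay, with a stated time of 24 h, tested at 33.33 ug/mL; on this read-out lower numbers stand for a weaker effect and higher numbers for a stronger effect at the one concentration tested; compound 2 gives 11.2%, while compound 1 `CCc1ccc2nc(C(=O)Nc3c(F)cc(-c4cccc(F)c4)cc3F)c(C)c(O)c2c1` gives 56.3%. Among the measured compounds shown here, the only measured step is a number 45.1 percentage points lower from compound 1 to compound 2 (beyond the scatter), a change on an aromatic carbon that cuts the read-out sharply. Compound 3 `Cc1c(C(=O)Nc2c(F)cc(-c3cccc(F)c3)cc2F)nc2ccc(OC(F)(F)F)cc2c1O` remains to be measured in this assay. Compound 3 differs from compound 2 by trifluoromethyl in place of ethyl on an oxygen on an aromatic ring. For the measured compounds named here, no measured step touches the oxygen of the ethoxy group, so the one step on record, from ethyl to ethoxy, does not bear directly on this change. With nothing to build on beyond the shared oxygen, the expectation for compound 3 is a small step, a number 6.8 percentage points higher from compound 2 to compound 3 (within the scatter), not beyond the scatter, and the estimate for compound 3 in this assay is 18%, with a range from 4% to 40%.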

Compound 3, a percentage reported as inhibition, at one concentration (the size of the read-out at that concentration, not a potency): 41.3%
Compound 3: the middle estimate sits 23.3 percentage points below what was measured; measured number outside the range, above it.
By their numbers in this assay, from the lowest: compound 2; then compound 3; then compound 1.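

In this assay, the group carried on the oxygen decides the outcome: trifluoromethyl in place of ethyl gives a number 30.1 percentage points higher from compound 2 to compound 3 (beyond the scatter), so an oxygen on the aromatic ring does not by itself hold the read-out as low as in compound 2. The recovery is partial, since trifluoromethoxy in place of ethyl on the aromatic carbon still gives a number 15 percentage points lower from compound 1 to compound 3 (beyond the scatter), and compound 1, with both of its steps beyond the scatter, stays the highest of the three. No measurement at hand explains either step.

From the compounds shown here alone, whether the read-out at this place follows the atom bonded to the ring or the group further out remains open. A methoxy group, an amine or a longer chain such as propyl would help separate the two, and a read-out at one concentration tells only how strong the effect is at that concentration.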